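Phenyl to pyridin-4-yl on compound 2

This account rests on a few compounds, and the source may have more. Where it says the series, first, only, none or still open, it means among the compounds named here.

In an ADME assay (liver) for metabolic stability, with Liver microsome (Rattus norvegicus) as the target, using microsomes (on this read-out lower numbers stand for slow clearance and higher numbers for fast clearance), compound 1 (`c1ccc(CNc2nnc(-c3ccc4cnccc4c3)o2)cc1`) stands at 166 mL.min-1.g-1 and compound 2 (`c1ccc(CNc2nnc(-c3c[nH]c4ncccc34)o2)cc1`) at 40 mL.min-1.g-1 as the lower of the two numbers, a gap beyond the usual scatter. Compound 3 (`c1cnc2[nH]cc(-c3nnc(NCc4ccncc4)o3)c2c1`), still unmeasured, differs from compound 2 by a single change (pyridin-4-yl in place of phenyl on a saturated chain carbon bound to a nitrogen on an aromatic ring). Going by the values given here, no measured pair shows this change, so the expectation is tentative: a modest fall in this assay, slightly beyond the scatter. The estimate is a 2.2-fold lower number from compound 2 to compound 3 (0.35 log units; beyond the scatter) as the expected step. For compound 3 the estimated value is 18 mL.min-1.g-1 (expected range 7 mL.min-1.g-1 to 42 mL.min-1.g-1) until a measurement arrives.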

Compound 3, intrinsic clearance in microsomes: 37 mL.min-1.g-1
For compound 3 the middle estimate is 2.1-fold (0.31 log units) below the measured one; the measured number falls inside the stated range.
By their numbers in this assay, from the lowest: compounds 3 and 2 (each within the scatter of the next); then compound 1.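

In this assay the first pair differing in one place gives a 1.1-fold lower number from compound 2 to compound 3 (0.03 log units; within the scatter) and so shows that, on a saturated chain carbon bound to a nitrogen on an aromatic ring, pyridin-4-yl and phenyl cannot be told apart on this read-out. The added hydrogen-bond acceptor of pyridin-4-yl leaves the number within the scatter here. Nothing available accounts for this result. Open, as far as these compounds go, is whether pyridin-2-yl, a carboxylic acid or a longer chain at this place would shift the number, and whether pyridin-4-yl would give a similar step on the core of compound 1.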